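Two Limits Measured, a Third Compound Awaits

The source may hold more compounds than are shown below. What is called first, only, known or untested is meant among the compounds shown, and "the series" means these compounds.

compound 1 `COc1cc(OC)c(C(=O)/C=C/c2ccc(N(C)C)cc2)c(O)c1CC=C(C)C` — > 100000 nM
compound 2 `CCCCc1c(OC)cc(OC)c(C(=O)/C=C/c2cccc(N3CCNCC3)c2)c1O` — > 100000 nM

In an ADME assay on MCF7-DOX cells (Homo sapiens) for cytotoxicity, read by MTT assay, with a stated time of 48 h (a lower number here means a stronger inhibitor, a higher number a weaker inhibitor), compound 1 gives > 100000 nM, which is a limit of the assay and not a number. Compound 2 in this assay likewise gives > 100000 nM, again a limit. Compound 1 therefore stands at the limit of > 100000 nM in this assay, at which 2 of the 2 values shown sit, and no measured step joins any two of these compounds, so no measured size of change exists. The unmeasured compound 3 `COc1cccc(/C=C/C(=O)c2c(OC)cc(OC)c(CC=C(C)C)c2O)c1` differs from compound 1 in one place: 3-methoxyphenyl in place of 4-(dimethylamino)phenyl on a double-bonded chain carbon bound to a double-bonded chain carbon. With both measured values sitting at the limit, compound 3 is expected to sit there too, and the step of a number no higher from compound 1 to compound 3 (the limit leaves the size open) is expected to be none beyond the scatter in this assay. For compound 3 the estimate in this assay is 100000 nM, within 30000 nM to 300000 nM, with a fair chance that the assay again reports only a limit.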

Compound 3, half-maximal inhibitory concentration: 49200 nM
The estimate for compound 3 lay 2.0-fold (0.31 log units) above the measured number; the range from low to high includes it.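

The change at this place is enough to move the read-out off the limit: replacing 4-(dimethylamino)phenyl with 3-methoxyphenyl on a double-bonded chain carbon bound to a double-bonded chain carbon gives, in this assay, an at least 2.0-fold lower number from compound 1 to compound 3 (0.30 log units; that floor lies within the scatter). On these data alone, the printed floor of this step does not pass the scatter, and its full size stays unknown, so the result shows a direction that may be no larger than repeat measurements would produce. Compound 3 is the only compound of the three with a number rather than a limit: the limit of > 100000 nM in this assay, at which 2 of the 3 values shown sit.

As far as these compounds go, what a 4-methoxyphenyl, a 3-(dimethylamino)phenyl or a plain phenyl would give at this place remains open. The compounds shown therefore do not separate the effect of the group itself from that of where it sits on the phenyl.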